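Pyridinylmethyl amide of a hydroxy-oxo core: expected paw edema inhibition

A few compounds are considered here, and "the series" means these few. Any claim that something is new, unique, unknown or untested is made for them only; others in the source may bear on it.

Measured compounds:
compound 1 `CNC(=O)c1c(O)c2cccnc2n(-c2ccccc2)c1=O`: 21%
compound 2 `O=C(NCc1ccccc1)c1c(O)c2cccnc2n(-c2ccccc2)c1=O`: 11.3%
compound 3 `O=C(Nc1ccc([N+](=O)[O-])cc1)c1c(O)c2cccnc2n(-c2ccccc2)c1=O`: -25.8%

In a functional assay on the whole organism for inhibition, with Rattus norvegicus as the target, read by cytopathic effect and paw edema, at a dose of 100 mg/kg by the oral route (on this read-out higher numbers stand for more inhibition at the one dose given (going by the name of the read-out) and lower numbers for less inhibition), compound 1 gives 21%, the highest of the three numbers in hand; compound 2 sits nearest, and the step of a number 9.7 percentage points lower from compound 1 to compound 2 (within the scatter) lies within the scatter, so the two cannot be ordered. Compound 3 lies furthest, and the step of a number 46.8 percentage points lower from compound 1 to compound 3 (beyond the scatter) is large and beyond the scatter, as is the step of a number 37.1 percentage points lower from compound 2 to compound 3 (beyond the scatter).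

Compound 4 `O=C(NCc1ccncc1)c1c(O)c2cccnc2n(-c2ccccc2)c1=O` is not yet measured. It differs from compound 1 by pyridin-4-yl in place of hydrogen on a saturated chain carbon bound to an amide-type nitrogen. Within the data shown here, the step that bears most closely on this change is the one from compound 1 to compound 2, where a phenyl entered at the same place and the number moved only within the scatter, a number 9.7 percentage points lower from compound 1 to compound 2 (within the scatter). The steps to compound 3 concern a different change, the 4-nitrophenyl on the amide-type nitrogen, and therefore give little guidance here. The change from compound 1 to compound 4 is thus expected to produce a step of a number 8 percentage points lower from compound 1 to compound 4 (within the scatter) in this assay, no larger than the scatter and, if anything, toward a lower number, as the value of compound 2, 11.3%, suggests. Compound 4 is accordingly estimated at 13%, with a range from -5% to 30%.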

Compound 4, a percentage reported as inhibition, in the whole organism at one dose (the size of the read-out at that dose, not a potency): 15.4%
Compound 4: the middle estimate sits 2.4 percentage points below what was measured; the measured number falls inside the stated range.
By their numbers in this assay, from the lowest: compound 3; then compounds 2, 4 and 1 (each within the scatter of the next).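

In this assay, replacing phenyl with pyridin-4-yl on the saturated chain carbon bound to the amide-type nitrogen gives a number 4.1 percentage points higher from compound 2 to compound 4 (within the scatter), so this ring exchange produces no readable change. Compared with the hydrogen of the methyl amide, the pyridin-4-yl group gives a number 5.6 percentage points lower from compound 1 to compound 4 (within the scatter), so a second aromatic ring at this carbon now joins phenyl in staying within the scatter, and compounds 1, 2 and 4 cannot be ordered. Compound 3 remains apart, with (pyridin-4-yl)methyl in place of 4-nitrophenyl on the amide-type nitrogen giving a number 41.2 percentage points higher from compound 3 to compound 4 (beyond the scatter), a large gap of the same kind already seen with the methyl and benzyl amides, though nothing available bears on the reason for any of these steps.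

As far as these compounds go, it remains open whether the low number of compound 3 goes with the nitro group or with an aromatic ring placed directly on the amide-type nitrogen, a question that a plain phenyl or a 4-nitrobenzyl group on that nitrogen could separate. Also open, from the compounds shown here alone, is whether pyridin-2-yl, a longer chain such as 2-(pyridin-4-yl)ethyl, or a carboxylic acid at this place would move the number beyond the scatter.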